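The compounds below may be only part of what the source reports. "The series", "measured", "known", "first", "only" and "open" are said of these compounds alone.

Measured compounds, with their values in a functional assay on MCF7 cells (Homo sapiens) for cytotoxicity, read by MTT assay, with a stated time of 48 h; a higher number here means a weaker inhibitor, a lower number a stronger inhibitor:
Compound 1, `CCCCCCCCCCCCNC(=O)[C@@H](NC(=O)c1ccco1)[C@@H](C)O`: compound 1 gives 67500 nM.
Compound 2, `CCCCCCCCCCCCNC(=O)[C@@H](NC(=O)c1cc2ccccc2o1)[C@@H](C)O`: compound 2 gives 20900 nM.
Compound 3, `CCCCCCCCCCCCNC(=O)[C@@H](NC(=O)c1cc2ccccc2n1C)[C@@H](C)O`: compound 3 gives 31300 nM.

Compound 1 stands at the highest of the three numbers. Its nearest neighbour is compound 3, reached by a 2.2-fold lower number from compound 1 to compound 3 (0.33 log units; beyond the scatter); the furthest is compound 2, reached by a 3.2-fold lower number from compound 1 to compound 2 (0.51 log units; beyond the scatter). Between the two larger variants the step of a 1.5-fold higher number from compound 2 to compound 3 (0.18 log units; within the scatter) lies within the scatter. Within the data shown here, all three numbers sit in a narrow band, and the series so far varies only the aromatic ring attached to the carbonyl.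

Compound 4, `CCCCCCCCCCCCNC(=O)[C@@H](NS(=O)(=O)c1cccs1)[C@@H](C)O`, is not yet measured in this assay. It differs from compound 1 in one place: (thiophen-2-yl)sulfonyl in place of (furan-2-yl)carbonyl on an amine nitrogen. Among the measured compounds shown here, the carbonyl thereby gives way to a sulfonyl, a change none of the measured steps touches; each of them kept the carbonyl and exchanged furan-2-yl for 1-benzofuran-2-yl or 1-methyl-1H-indol-2-yl. For the measured compounds named here, no measured step bears directly on the change, so the expected size of the step in this assay rests only on the narrow band seen so far. The expected step from compound 1 to compound 4 is a 1.1-fold lower number from compound 1 to compound 4 (0.05 log units; within the scatter), with no firm direction. Compound 4 is expected to give 60000 nM in this assay, within a range of 20000 nM to 150000 nM.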

Compound 4, half-maximal inhibitory concentration: 19100 nM
For compound 4 the middle estimate is 3.1-fold (0.50 log units) above the measured one, outside the stated range (below it).
By their numbers in this assay, from the lowest: compounds 4, 2 and 3 (each within the scatter of the next); then compound 1.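

In this assay, the amine nitrogen of the core accepts a sulfonyl link as well as a carbonyl link: replacing (furan-2-yl)carbonyl with (thiophen-2-yl)sulfonyl gives a 3.5-fold lower number from compound 1 to compound 4 (0.55 log units; beyond the scatter), a step of modest size and the first in the series to alter the link itself. Compound 4 now falls in one group with compounds 2 and 3, each within the scatter of the next, while compound 1 remains apart with the highest number, so a carbonyl link is not required for a number in this group; however, this step changes the ring and the link together, and the two contributions cannot be separated. Nothing available explains why the number moves at this position.

Open, as far as these compounds go, is whether (thiophen-2-yl)carbonyl or (furan-2-yl)sulfonyl on the same nitrogen would stand with compound 1 or with compound 4, a pair that would separate the ring from the link. Also open, from the compounds shown here alone, is whether a larger group such as (1-benzofuran-2-yl)sulfonyl or a benzenesulfonyl group would move the number beyond this group or stay within it.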